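The source may hold more compounds than are shown below. What is called first, only, known or untested is meant among the compounds shown, and "the series" means these compounds.

Three of the four compounds in this small set have been tested in an ADME assay on NIH3T3 cells (Mus musculus) for cytotoxicity, read by trypan blue exclusion, with a stated time of 48 h; on this read-out lower numbers stand for stronger inhibition and higher numbers for weaker inhibition. Compound 1 `Cn1cnc(C(=O)NNC(=O)COc2ccc(C(=O)c3ccccc3)cc2)c1` gives 98800 nM in this assay, compound 2 `Cn1cnc(C(=O)NNC(=O)COc2c(F)cc(C(=O)c3ccc(Cl)cc3)cc2Cl)c1` gives 90900 nM, and compound 3 `O=C(COc1ccc(C(=O)c2ccccc2)cc1)NNC(=O)c1ccc(=O)oc1` gives 84300 nM. Compound 1 and compound 3 differ in one place, (a group of 7 heavy atoms (5 carbon, 2 oxygen; one six-membered aromatic ring with 1 hetero atom) in place of a group of 6 heavy atoms (4 carbon, 2 nitrogen; one five-membered aromatic ring with 2 hetero atoms), on a carbonyl carbon), and that change made a step of a 1.2-fold lower number from compound 1 to compound 3 (0.07 log units; within the scatter). The difference between the core of compound 1 and the core of compound 2 is not broken down here. Compound 4 `O=C(COc1c(F)cc(C(=O)c2ccc(Cl)cc2)cc1Cl)NNC(=O)c1ccc(=O)oc1` has not yet been measured in this assay. It stands to compound 2 as compound 3 stands to compound 1: the change is a group of 7 heavy atoms (5 carbon, 2 oxygen; one six-membered aromatic ring with 1 hetero atom) in place of a group of 6 heavy atoms (4 carbon, 2 nitrogen; one five-membered aromatic ring with 2 hetero atoms), on a carbonyl carbon, the same change at the same place on the carbonyl carbon. Because the earlier step of a 1.2-fold lower number from compound 1 to compound 3 (0.07 log units; within the scatter) stayed within the scatter, a step of about the same size is expected here, a 1.1-fold lower number from compound 2 to compound 4 (0.06 log units; within the scatter). On that basis compound 4 is estimated to give 80000 nM in this assay, with a likely range from 40000 nM to 160000 nM.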

Compound 4, half-maximal inhibitory concentration: 79300 nM
Compound 4: middle estimate off by 1.0-fold (0.00 log units), on the high side; the measured number falls inside the stated range.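

In this assay, replacing the 1-methyl-1H-imidazol-4-yl group on the carbonyl carbon with the six-membered aromatic ring carrying one hetero atom gave a 1.1-fold lower number from compound 2 to compound 4 (0.06 log units; within the scatter). Among these compounds, the same change on the core of compound 1 gave a step of matching size, so on these two cores it carried over without a detectable difference: the same change on two cores in this assay, a 1.2-fold lower number (0.07 log units; within the scatter) from compound 1 to compound 3 and a 1.1-fold lower number (0.06 log units; within the scatter) from compound 2 to compound 4, 1.0-fold (0.01 log units) apart, within the scatter of two such steps This shows only that the change left the read-out within the scatter on both cores; since neither step stands clear of the scatter, the pair does not show that a real effect of this change transfers from one core to another, and two cores cannot establish a rule for the series.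

The compounds shown carry only these two groups on the carbonyl carbon, so it remains open how a carboxylic acid or an amine at that place would read out in this assay. Also open, going by these compounds, is whether a longer chain in the shared part of the structure would leave the change just as silent.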